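The source may hold more compounds than are shown below. What is called first, only, known or untested is meant among the compounds shown, and "the series" means these compounds.

Compound 3 `O=S(=O)(c1cc(F)cc(F)c1)c1cnc2cc(F)ccc2c1-c1cccc(Cl)c1` gives 0.22 mL/min in an ADME assay on microsomes from liver (Homo sapiens) for metabolic stability, tested at 2.5 uM (on this read-out higher numbers stand for fast clearance and lower numbers for slow clearance), the lowest number among the three measured compounds: compound 1 `COc1ccc(S(=O)(=O)c2cnc3cc(F)ccc3c2-c2ccc(F)cc2)cc1Cl` gives 1.29 mL/min and compound 2 `COc1ccc(S(=O)(=O)c2cnc3cc(F)ccc3c2-c2cccc(F)c2)cc1Cl` gives 2.08 mL/min, both beyond the scatter from compound 3. For the measured compounds named here, the one measured step, a 1.6-fold higher number from compound 1 to compound 2 (0.21 log units; within the scatter), sits on the other aromatic carbon and does not touch the sulfonyl substituent. Compound 4 `COc1ccc(S(=O)(=O)c2cnc3cc(F)ccc3c2-c2cccc(Cl)c2)cc1Cl` differs from compound 3 in one place: 3-chloro-4-methoxyphenyl in place of 3,5-difluorophenyl on a sulfonyl sulfur. Going by the values given here, no measured pair isolates this change; compounds 1 and 2, which carry 3-chloro-4-methoxyphenyl on the sulfonyl sulfur, sit well above compound 3, but they also differ at the other aryl. An upward step is expected for compound 4, with wide uncertainty, about a 4.5-fold higher number from compound 3 to compound 4 (0.66 log units; beyond the scatter). Compound 4 is estimated at 1 mL/min, between 0.35 mL/min and 2.5 mL/min.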

Compound 4, intrinsic clearance in a liver preparation (reported as CLH), per the amount of preparation that the assay uses: 1.19 mL/min
Estimate against measurement, compound 4: 1.2-fold (0.08 log units) below; measured number inside the range.
By their numbers in this assay, from the lowest: compound 3; then compounds 4, 1 and 2 (each within the scatter of the next).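

In this assay, a 5.4-fold higher number from compound 3 to compound 4 (0.73 log units; beyond the scatter) gives the first matched read of this change on a sulfonyl sulfur, with the rest of the structure held fixed. The gap between the sulfonyl groups therefore stands without any difference at the other aryl. With 3-chloro-4-methoxyphenyl kept on the sulfonyl sulfur, changes at the other aryl stay small: a 1.7-fold lower number from compound 2 to compound 4 (0.24 log units; within the scatter) and a 1.1-fold lower number from compound 1 to compound 4 (0.04 log units; within the scatter).

Nothing available gives a reason for the step at the sulfonyl sulfur. Open, on these data alone, is whether the chloro or the methoxy of the entering group carries the step, and how an amine on that aryl would read.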